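Replacing a Methylphenyl Group with a Methoxy-Bearing Chain

The source may report more compounds than this note shows. Statements on the series, on what has been measured and on what is new or still open speak of the compounds shown alone.

Compound 1 `Cc1cccc([C@@H](O)C(=O)N2N=CC[C@H]2C(=O)NCc2cc(Cl)ccc2-n2cnnn2)c1` was measured in an ADME assay on Caco-2 cells (Homo sapiens) for permeability, read by LC-MS, in the apical to basolateral direction, with a stated time of 60 min, at pH 6.5 (a higher number here means that the compound crosses the layer faster, a lower number that the compound crosses the layer more slowly), and gave 9.7 10^-6 cm/s. Its companion in the same series, compound 2 `O=C(NCc1cc(Cl)ccc1-n1cnnn1)[C@@H]1[C@H]2C[C@H]2CN1C(=O)[C@H](O)c1ccccc1`, gave 12 10^-6 cm/s in this assay; the gap between the two numbers lies within the scatter, so neither compound can be said to cross the layer faster than the other. Compound 1 therefore stands at one end of these two numbers without being distinguishable from compound 2. The still untested compound 3 `COC(C)(C)[C@@H](O)C(=O)N1N=CC[C@H]1C(=O)NCc1cc(Cl)ccc1-n1cnnn1` differs from compound 1 at a single position: 1-methoxy-1-methylethyl in place of 3-methylphenyl on a saturated chain carbon bound to a carbonyl carbon and an oxygen on a saturated carbon. Among the compounds with values here, no measured pair in this set shows what such a change does in this assay, so the size of the step rests on judgement alone. The account expects a modest downward step, a 1.6-fold lower number from compound 1 to compound 3 (0.21 log units; within the scatter), which may not exceed the scatter. On that basis compound 3 is estimated at 6 10^-6 cm/s in this assay, with a range from 3 10^-6 cm/s to 12 10^-6 cm/s.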

Compound 3, apparent permeability: 1.7 10^-6 cm/s
The estimate for compound 3 lay 3.5-fold (0.55 log units) above the measured number; measured number below the stated range.
By their numbers in this assay, from the lowest: compound 3; then compounds 1 and 2 (each within the scatter of the next).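

In this assay this position, on a saturated chain carbon bound to a carbonyl carbon and an oxygen on a saturated carbon, does respond to a change of group: 1-methoxy-1-methylethyl in place of 3-methylphenyl gives a 5.7-fold lower number from compound 1 to compound 3 (0.76 log units; beyond the scatter). Within the data shown here, this is the first pair in the set that differs in one place, so it is the first reading of any single change. Nothing at hand accounts for the size of this step.

The change removes the aromatic ring and brings in a methoxy oxygen at once, so the compounds shown cannot separate these two parts of it. A tert-butyl group, which has no such oxygen, or a cyclohexyl ring at this position would be needed to tell them apart.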